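The source may report more compounds than this note shows. Statements on the series, on what has been measured and on what is new or still open speak of the compounds shown alone.

Compound 1 `O=C(COc1ccc(-c2cc(=O)c3ccccc3o2)cc1)NC1CCN(Cc2ccccc2)CC1`: 15500 nM
Compound 2 `COc1ccc(CN2CCC(NC(=O)COc3ccc(-c4cc(=O)c5ccccc5o4)cc3)CC2)cc1`: 6800 nM
Compound 3 `O=C(COc1ccc2c(=O)cc(-c3ccccc3)oc2c1)NC1CCN(Cc2ccccc2)CC1`: 16700 nM

These numbers come from a functional assay on HepG2 cells (Homo sapiens) for cytotoxicity, read by MTT assay, with a stated time of 72 h; on this read-out higher numbers stand for weaker inhibition and lower numbers for stronger inhibition. Compound 3 has the highest number of the three, though compound 1 lies within the scatter of it; only compound 2 sits beyond the scatter, below it. Compound 4 `O=C(COc1ccc2c(=O)cc(-c3ccccc3)oc2c1)NC1CCN(Cc2ccc(C(F)(F)F)cc2)CC1` has not yet been measured; it differs from compound 3 by trifluoromethyl in place of hydrogen on an aromatic carbon. Among the compounds with values here, the one measured step that bears on this change is a 2.3-fold lower number from compound 1 to compound 2 (0.36 log units; beyond the scatter), which also swapped a hydrogen on an aromatic carbon of a benzyl group. That step was modest, and the entering group here is a different one, so in this assay a small step toward a lower number is expected, possibly none beyond the scatter. Compound 4 is estimated at 10000 nM, within 4000 nM to 25000 nM. The expected step is a 1.7-fold lower number from compound 3 to compound 4 (0.22 log units; within the scatter).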

Compound 4, half-maximal inhibitory concentration: 7200 nM
Beside the measured number, compound 4's estimate is 1.4-fold (0.14 log units) above it, and the stated range covers the measured number.
By their numbers in this assay, from the lowest: compounds 2 and 4 (each within the scatter of the next); then compounds 1 and 3 (each within the scatter of the next).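

Adding trifluoromethyl to the benzyl group in this assay gives a 2.3-fold lower number from compound 3 to compound 4 (0.37 log units; beyond the scatter) and shows that this position can respond on a second core and to a second group. Within the data shown here, the only earlier change at this position was methoxy on another core, which gave a 2.3-fold lower number from compound 1 to compound 2 (0.36 log units; beyond the scatter) and was also modest and in the same direction. No measurement shown explains why the number falls in either case. On these data alone, whether an amine or a carboxylic acid at this position would also lower the number remains open. Also open, as far as these compounds go, is whether each group would give a similar step on the other core.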